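Fluorophenyl dienones: ring hydroxylation and fluorine position

This account rests on a few compounds, and the source may have more. Where it says the series, first, only, none or still open, it means among the compounds named here.

The series is built on a cyclohexenyl dienone bearing a fluorophenyl terminus. Compound 1 `CC1=C(/C=C/C(=O)/C=C/c2ccccc2F)C(C)(C)CCC1` carries the 2-fluorophenyl group and, in a functional assay on PC-3 cells (Homo sapiens) for cytotoxicity, read by MTT assay, with a stated time of 72 h (a lower number here means a stronger inhibitor, a higher number a weaker inhibitor), compound 1 gives 22100 nM. Compound 2 `CC1=C(/C=C/C(=O)/C=C/c2cccc(F)c2)C(C)(C)CCC1` differs only in the ring position of the fluorine: 3-fluorophenyl in place of 2-fluorophenyl on a double-bonded chain carbon bound to a double-bonded chain carbon. The step of a 1.2-fold lower number from compound 1 to compound 2 (0.07 log units; within the scatter) shows that this change barely registers; in this assay compound 2 gives 18700 nM.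

Compound 3 `CC1=C(/C=C/C(=O)/C=C/c2ccccc2F)C(C)(C)CCC1O` keeps the 2-fluorophenyl group of compound 1 but adds a hydroxy group to the core: hydroxy in place of hydrogen on a saturated ring carbon. The step of a 2.1-fold lower number from compound 1 to compound 3 (0.33 log units; beyond the scatter) is the only one among the three measured compounds that clears the scatter. In this assay compound 3 gives 10400 nM, and the values of compound 2 and compound 3 sit within the usual scatter of each other, so no order between them is claimed.

Compound 4 `CC1=C(/C=C/C(=O)/C=C/c2cccc(F)c2)C(C)(C)CCC1O` is the still unmeasured member, carrying both the hydroxy group and the 3-fluorophenyl group. Its difference from compound 3 is 3-fluorophenyl in place of 2-fluorophenyl on a double-bonded chain carbon bound to a double-bonded chain carbon, the same change already made from compound 1 to compound 2, at the same place. On the strength of a 1.2-fold lower number from compound 1 to compound 2 (0.07 log units; within the scatter) being within the scatter, the step of a 1.2-fold lower number from compound 3 to compound 4 (0.08 log units; within the scatter) is expected to be small. Compound 4 is therefore estimated at 8700 nM, with a likely range from 4500 nM to 17000 nM.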

Compound 4, half-maximal inhibitory concentration: 16000 nM
Beside the measured number, compound 4's estimate is 1.8-fold (0.26 log units) below it, within the range that was stated.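

In this assay, 3-fluorophenyl in place of 2-fluorophenyl gives a 1.5-fold higher number from compound 3 to compound 4 (0.19 log units; within the scatter), and this step cannot be told apart from its counterpart on the core without the hydroxy group: the same change on two cores in this assay, a 1.2-fold lower number (0.07 log units; within the scatter) from compound 1 to compound 2 and a 1.5-fold higher number (0.19 log units; within the scatter) from compound 3 to compound 4, 1.8-fold (0.26 log units) apart, within the scatter of two such steps. Hydroxy in place of hydrogen on a saturated ring carbon gives a 1.2-fold lower number from compound 2 to compound 4 (0.07 log units; within the scatter), and although only the earlier counterpart is printed as beyond the scatter, the two steps likewise cannot be told apart: the same change on two cores in this assay, a 2.1-fold lower number (0.33 log units; beyond the scatter) from compound 1 to compound 3 and a 1.2-fold lower number (0.07 log units; within the scatter) from compound 2 to compound 4, 1.8-fold (0.26 log units) apart, within the scatter of two such steps. Within these four compounds, both changes therefore carry from one core to the other without a resolved difference, but this does not show that the steps are equal, nor does it establish that the effect of the hydroxy group is independent of the fluorine position or dependent on it.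

From the compounds shown here alone, it remains open how the series would respond to an amine or a carboxylic acid in place of the hydroxy group on the saturated ring carbon, or to chlorine or a methoxy group in place of fluorine on the phenyl ring. Going by these compounds, it also remains open whether a larger set of matched pairs would separate the hydroxy step on the 2-fluorophenyl core from the same step on the 3-fluorophenyl core.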